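The source may hold more compounds than are shown below. What is called first, only, known or untested is meant among the compounds shown, and "the series" means these compounds.

Measured so far:
compound 1, `COc1ccc(-c2ccc(-c3ccc(C(=N)N)cc3)s2)cc1`, gives 811 nM
compound 2, `N=C(N)c1ccc(-c2ccc(-c3cc(Cl)cc(Cl)c3)s2)cc1`, gives 1200 nM

In a functional assay on SNB-19 cells (Homo sapiens) for inhibition, read by sulforhodamine B assay, with a stated time of 48 h (a higher number here means a weaker inhibitor of growth, a lower number a stronger inhibitor of growth), compound 1 has the lower of the two numbers, and compound 2 sits so close that the two cannot be told apart within the usual scatter. Among the compounds with values here, no step between two measured compounds that differ in one place is available, so nothing is known yet about how a single change on the outer ring shifts the number.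

Compound 3, `N=C(N)c1ccc(-c2ccc(-c3ccc(F)cc3)s2)cc1`, differs from compound 1 in one place: fluoro in place of methoxy on an aromatic carbon. Within the data shown here, since no measured step is there to lean on, the expectation is that the change from compound 1 to compound 3 gives at most a small shift in this assay, with a slight lean toward a higher number, and quite possibly no change beyond the scatter, so a 1.2-fold higher number from compound 1 to compound 3 (0.09 log units; within the scatter) is the expected step. Compound 3 is therefore estimated at 1000 nM, with a likely range from 400 nM to 2500 nM.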

Compound 3, concentration for 50% growth inhibition: 1930 nM
For compound 3 the middle estimate is 1.9-fold (0.29 log units) below the measured one; low and high end bracket the measured number.
By their numbers in this assay, from the lowest: compounds 1, 2 and 3 (each within the scatter of the next, the first and the last beyond it).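

Putting fluoro in place of methoxy on this aromatic carbon, para to a large group, gives a 2.4-fold higher number from compound 1 to compound 3 (0.38 log units; beyond the scatter) in this assay. Within the data shown here, this is the first sign that the group at this position can move the number, although the step is modest and the pair with methoxy has the stronger growth inhibition. Nothing at hand gives a reason for this shift.

One pair cannot show whether methoxy improves the number or fluoro worsens it, and a plain hydrogen at the same place would be the natural reference for telling these apart. Also open, from the compounds shown here alone, is how an amine, a hydroxyl or a longer chain such as ethoxy on this carbon would compare, and whether the step would stay the same on a different core.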